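Moving the chlorine on the benzylsulfanyl group

The source may report more compounds than this note shows. Statements on the series, on what has been measured and on what is new or still open speak of the compounds shown alone.

Three compounds of a shared core were measured in a functional assay on the whole organism (artery, strain albino) with Rattus norvegicus as the target, with a stated time of 60 min, at a dose of 10 mg/kg by the oral route; a higher number here means more inhibition at the dose given (going by the name of the read-out), a lower number less inhibition. Compound 1 `CC1=C(C(=O)Nc2ccc([N+](=O)[O-])cc2)C(c2ccc(Br)cc2)N=C(SCc2cccc(Cl)c2)N1` gives 4.1%. Compound 2 `CC1=C(C(=O)Nc2ccc([N+](=O)[O-])cc2)C(c2cccc([N+](=O)[O-])c2)N=C(SCc2ccccc2)N1` gives 7.7%, and compound 3 `CC1=C(C(=O)Nc2ccc([N+](=O)[O-])cc2)C(c2cccc([N+](=O)[O-])c2)N=C(SCc2ccccc2Cl)N1` gives 6.7%. Compound 3 stands second of the three, with compound 2 nearest and compound 1 furthest, and all three values lie within the usual scatter of one another. Among the measured compounds shown here, the only single-point step among them, a number 1 percentage points lower from compound 2 to compound 3 (within the scatter), is within the scatter.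

Compound 4 `CC1=C(C(=O)Nc2ccc([N+](=O)[O-])cc2)C(c2cccc([N+](=O)[O-])c2)N=C(SCc2cccc(Cl)c2)N1` differs from compound 3 in one place: 3-chlorophenyl in place of 2-chlorophenyl on a saturated chain carbon bound to a sulfur. For the measured compounds named here, no measured step moves a chlorine from one position of the benzyl ring to another. Going by the values given here, compound 1 carries the 3-chlorobenzyl group, but its other aryl group also differs from that of compound 3, so its value shows only that such a compound sits near the others. Among the compounds with values here, the one step touching the chloro group, a number 1 percentage points lower from compound 2 to compound 3 (within the scatter), was within the scatter, so no change beyond the scatter is expected in this assay. Compound 4 is therefore expected to give 6%, between 0% and 14%. The expected step is a number 0.7 percentage points lower from compound 3 to compound 4 (within the scatter).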

Compound 4, a percentage reported as inhibition, in the whole organism at one dose (the size of the read-out at that dose, not a potency): 8.2%
For compound 4 the middle estimate is 2.2 percentage points below the measured one, within the range that was stated.
By their numbers in this assay, from the lowest: compounds 1, 3, 2 and 4 (each within the scatter of the next).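

The move from 2-chlorobenzyl to 3-chlorobenzyl can now be read directly in this assay as a number 1.5 percentage points higher from compound 3 to compound 4 (within the scatter) and does not separate the two groups on a saturated chain carbon bound to a sulfur. Chloro in place of hydrogen on the aromatic carbon, now with the 3-chlorobenzyl group, reads as a number 0.5 percentage points higher from compound 2 to compound 4 (within the scatter) and so, like a number 1 percentage points lower from compound 2 to compound 3 (within the scatter) for the 2-chlorobenzyl group, stays within the scatter. Among the compounds shown here, the first single-place reading of the other aryl group, 3-nitrophenyl in place of 4-bromophenyl on a saturated ring carbon, is a number 4.1 percentage points higher from compound 1 to compound 4 (within the scatter) and also does not separate the two groups.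

As far as these compounds go, whether an amine or a carboxylic acid on the benzyl ring, or a longer chain before it, would give a step beyond the scatter remains open. Nothing available accounts for these values.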